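The compounds below may be only part of what the source reports. "The series", "measured", "known", "first", "only" and "open" are said of these compounds alone.

In a functional assay on K562 cells (Homo sapiens) for inhibition (on this read-out higher numbers stand for weaker inhibition of growth and lower numbers for stronger inhibition of growth), compound 1 `O=C(/C=C/c1cccc(O)c1)c1cccc(-n2cc(-c3ccccc3)[nH]c2=O)c1` gives 3350 nM, while compound 2 `O=C(/C=C/c1cccc(O)c1)c1cccc(-n2cc(-c3ccc(Cl)cc3)[nH]c2=O)c1` gives 400 nM; the step of an 8.4-fold lower number from compound 1 to compound 2 (0.92 log units; beyond the scatter) is the only one measured so far, and it leaves compound 2 with the lowest number of the two. Compound 3 `COc1cc(/C=C/C(=O)c2cccc(-n3cc(-c4ccc(Cl)cc4)[nH]c3=O)c2)ccc1O` carries 4-hydroxy-3-methoxyphenyl in place of 3-hydroxyphenyl on a double-bonded chain carbon bound to a double-bonded chain carbon. For the measured compounds named here, no measured step touches this part of the molecule; the single recorded step concerns a different position, so it offers no direction here. The step of no change at the digits printed from compound 2 to compound 3 (within the scatter) is therefore expected to stay within the scatter. Compound 3 is estimated at 400 nM in this assay, within 130 nM to 1300 nM.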

Compound 3, concentration for 50% growth inhibition: 1420 nM
Compound 3: middle estimate off by 3.6-fold (0.55 log units), on the low side; the measured number lies above the stated range.
By their numbers in this assay, from the lowest: compound 2; then compound 3; then compound 1.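

In this assay, the group on the double-bonded chain carbon does affect the read-out: 4-hydroxy-3-methoxyphenyl in place of 3-hydroxyphenyl gives a 3.6-fold higher number from compound 2 to compound 3 (0.55 log units; beyond the scatter). For the compounds shown here, this is the first measured step at this position, and the chloro group stays unchanged across it. No available evidence accounts for the step. The change alters the hydroxy placement and adds methoxy together, so their separate contributions remain unresolved. Going by these compounds, a plain 4-hydroxyphenyl would separate them, and whether an aminophenyl or a carboxylic acid fits here remains open.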